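Amide to urea on a pyrazole series of growth inhibitors

The compounds below may be only part of what the source reports. "The series", "measured", "known", "first", "only" and "open" are said of these compounds alone.

Of the compounds shown here, two have been tested. Compound 1 `COc1cc(-c2nn(-c3cccc(NC(=O)Nc4cc(C(F)(F)F)cc(C(F)(F)F)c4)c3)cc2-c2ccncc2)ccc1Cl` gives 851 nM in a functional assay on SK-MEL-28 cells (Homo sapiens) for inhibition, read by sulforhodamine B assay, with a stated time of 48 h (a higher number here means a weaker inhibitor of growth, a lower number a stronger inhibitor of growth), while compound 2 `COc1cc(-c2nn(-c3cccc(NC(=O)c4cccc(C(F)(F)F)c4)c3)cc2-c2ccncc2)ccc1Cl` gives 2490 nM, the higher of the two numbers and therefore the weaker growth inhibitor, by a gap beyond the usual scatter. As far as these compounds go, compound 3 `COc1cc(-c2nn(-c3cccc(NC(=O)Nc4ccc(Cl)c(C(F)(F)F)c4)c3)cc2-c2ccncc2)ccc1Cl` is untested; it differs from compound 2 by (4-chloro-3-(trifluoromethyl)phenyl)amino in place of 3-(trifluoromethyl)phenyl on a carbonyl carbon, which brings this part of the molecule closer to compound 1. Because compound 1 reaches 851 nM, the step from compound 2 to compound 3 is expected to be a clear fall, about a 3.3-fold lower number from compound 2 to compound 3 (0.52 log units; beyond the scatter). Compound 3 is therefore estimated at 750 nM, between 280 nM and 2000 nM.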

Compound 3, concentration for 50% growth inhibition: 1200 nM
Beside the measured number, compound 3's estimate is 1.6-fold (0.20 log units) below it, and the stated range covers the measured number.
By their numbers in this assay, from the lowest: compounds 1 and 3 (each within the scatter of the next); then compound 2.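

In this assay, putting (4-chloro-3-(trifluoromethyl)phenyl)amino on the carbonyl carbon gives a 2.1-fold lower number from compound 2 to compound 3 (0.32 log units; beyond the scatter) as a modest step beyond the scatter. Compound 3 is a second urea whose value lies within the scatter of that of compound 1, so this position holds two differently substituted aryl ureas with no measurable separation. No data here explain the step.

As far as these compounds go, the change adds the urea nitrogen and the chlorine together, so their separate shares remain unknown. From the compounds shown here alone, whether a thiourea or a sulfonamide would serve at this position also remains open.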